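Replacing a Ring with Formylamino: Expected Cytotoxicity Outcome

The source may hold more compounds than are shown below. What is called first, only, known or untested is meant among the compounds shown, and "the series" means these compounds.

Three compounds built on one shared core have been examined in an ADME assay on L02 cells (Homo sapiens) for cytotoxicity, read by MTT assay, with a stated time of 48 h; a higher number here means a weaker inhibitor, a lower number a stronger inhibitor. Compound 1 `O=C1O[C@@H](CN2CCC(c3ccc(F)cc3)CC2)CN1c1ccc(-n2cc(-c3ccccn3)cn2)c(F)c1` reaches only the limit of this assay, giving > 400 ug/mL, which is a limit rather than a number. Compound 2 `O=C1CNC(=O)N1C[C@H]1CN(c2ccc(-n3cc(-c4ccccn4)cn3)c(F)c2)C(=O)O1` likewise gives > 400 ug/mL in this assay, again a limit and not a measured number. Among the measured compounds shown here, compound 3 `O=C1O[C@@H](Cn2ccnn2)CN1c1ccc(-n2cc(-c3ccccn3)cn2)c(F)c1` is the only one with a definite number, giving 49 ug/mL in this assay. For the measured compounds named here, the single measured step, an at least 8.1-fold lower number from compound 2 to compound 3 (0.91 log units; beyond the scatter), is therefore read against the fact that two of the three values sit at the limit, (the limit of > 400 ug/mL in this assay, at which 2 of the 3 values shown sit).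

Compound 4 `O=CNC[C@H]1CN(c2ccc(-n3cc(-c4ccccn4)cn3)c(F)c2)C(=O)O1` differs from compound 2 in one place: formylamino in place of 2,5-dioxoimidazolidin-1-yl on a saturated chain carbon bound to a saturated ring carbon. The step to compound 3 is the one that bears on this change, since it also removed the 2,5-dioxoimidazolidin-1-yl group from the same saturated chain carbon, and it lowered the number at least modestly. Formylamino, however, brings no ring, so whether the number moves as far is open. Compound 4 is expected to give about 380 ug/mL in this assay, with a plausible range from 120 ug/mL to 800 ug/mL. That expectation corresponds to an at least 1.0-fold lower number from compound 2 to compound 4 (0.02 log units; that floor lies within the scatter), most likely a value again reported only as a limit.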

Compound 4, half-maximal inhibitory concentration: > 400 ug/mL
Compound 4 ended at the assay's limit (the forecaster's own chance of this, stated with the estimate: 65%); middle value at least 1.0-fold (0.02 log units) away from the limit.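

In this assay the saturated chain carbon bound to a saturated ring carbon now carries formylamino, which brings no ring, and compound 4 gives > 400 ug/mL, a limit of the assay and not a number. Set against the compound with 1H-1,2,3-triazol-1-yl on that carbon, this change shows an at least 8.1-fold higher number from compound 3 to compound 4 (0.91 log units; beyond the scatter), so taking 2,5-dioxoimidazolidin-1-yl away does not by itself bring the number down, and of the groups shown on this carbon only 1H-1,2,3-triazol-1-yl goes with a definite value. The step between compound 2 and compound 4 cannot be read, because both values are limits: the limit of > 400 ug/mL in this assay, at which 3 of the 4 values shown sit.

The compounds shown leave open whether a definite value needs the 1H-1,2,3-triazol-1-yl ring itself, or whether another group on this carbon, such as a 1H-1,2,4-triazol-1-yl ring, a primary amine or an acetylamino group, would also give one. Going by these compounds, how far compound 1, compound 2 and compound 4 lie past the limit also stays unknown, so no order among them can be given.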